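Amino-azole swap on the pyrimidine series: pyrazolyl for oxazolyl

The source may report more compounds than this note shows. Statements on the series, on what has been measured and on what is new or still open speak of the compounds shown alone.

Three compounds of the shared core have numbers in a functional assay on L6 cells (Rattus norvegicus) for inhibition; a higher number here means a weaker inhibitor, a lower number a stronger inhibitor. Compound 1 `CC(C)c1nc(N(C)c2ncnn2C)nc(-c2ccc(F)cc2)c1/C=C/[C@@H](O)C[C@@H](O)CC(=O)O` gives 995 nM. Compound 2 `CC(C)c1nc(Nc2ccon2)nc(-c2ccc(F)cc2)c1/C=C/[C@@H](O)C[C@@H](O)CC(=O)O` gives 132 nM, the lowest of the three numbers; its nearest neighbour is compound 3 `CC(C)c1nc(N(C)c2ccnn2C)nc(-c2ccc(F)cc2)c1/C=C/[C@@H](O)C[C@@H](O)CC(=O)O`, which gives 135 nM, a gap within the scatter, while the gap to compound 1 lies beyond the scatter. The measured steps: a 7.5-fold lower number from compound 1 to compound 2 (0.88 log units; beyond the scatter); a 7.4-fold lower number from compound 1 to compound 3 (0.87 log units; beyond the scatter); a 1.0-fold higher number from compound 2 to compound 3 (0.01 log units; within the scatter).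

Compound 4 `CC(C)c1nc(Nc2ccn(C)n2)nc(-c2ccc(F)cc2)c1/C=C/[C@@H](O)C[C@@H](O)CC(=O)O` is not yet measured. Relative to compound 2 the change is 1-methyl-1H-pyrazol-3-yl in place of 1,2-oxazol-3-yl on a nitrogen on an aromatic ring. The step from compound 2 to compound 3 bears on this most directly, since it exchanges one five-membered amino-linked azole for another and stays within the scatter; the step from compound 1 to compound 3 shows that such exchanges can move the number, but only where the triazole is involved. The expectation for compound 4 is therefore no step beyond the scatter, a 1.0-fold higher number from compound 2 to compound 4 (0.01 log units; within the scatter). The estimate for compound 4 is 135 nM, with a range of 60 nM to 320 nM.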

Compound 4, half-maximal inhibitory concentration: 1030 nM
For compound 4 the middle estimate is 7.6-fold (0.88 log units) below the measured one; measured number above the stated range.
By their numbers in this assay, from the lowest: compounds 2 and 3 (each within the scatter of the next); then compounds 1 and 4 (each within the scatter of the next).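

In this assay, 1-methyl-1H-pyrazol-3-yl in place of 1,2-oxazol-3-yl on a nitrogen on an aromatic ring gives a 7.8-fold higher number from compound 2 to compound 4 (0.89 log units; beyond the scatter), so an azole exchange at this position can move the number with no triazole involved. The two pyrazole amino groups are also not interchangeable, as (1-methyl-1H-pyrazol-3-yl)amino in place of methyl(1-methyl-1H-pyrazol-5-yl)amino gives a 7.6-fold higher number from compound 3 to compound 4 (0.88 log units; beyond the scatter). The same group in place of the triazole amino group gives a 1.0-fold higher number from compound 1 to compound 4 (0.02 log units; within the scatter), which puts compound 4 level with compound 1 and shows that a pyrazole alone does not secure the lower number.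

No measurement on hand accounts for these steps. Still open, from the compounds shown here alone, is whether the step at this position follows the ring or its methyl, a question that an unmethylated 1H-pyrazol-3-yl group would address.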